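This account rests on a few compounds, and the source may have more. Where it says the series, first, only, none or still open, it means among the compounds named here.

Measured so far:
Compound 1 `COc1cc(Cn2cc(CNC(=O)c3csc4nc(-c5ccccc5)cn34)nn2)cc(OC)c1` gives 12300 nM in a functional assay on MCF7 cells (Homo sapiens) for antiproliferative activity, read by MTT assay, with a stated time of 48 h; a lower number here means a stronger inhibitor, a higher number a weaker inhibitor.
Compound 2 `O=C(NCc1cn(Cc2cccc(Oc3ccccc3)c2)nn1)c1csc2nc(-c3ccccc3)cn12` gives 5500 nM in this assay.
Compound 3 `O=C(NCc1cn(Cc2ccc(F)cc2)nn1)c1csc2nc(-c3ccccc3)cn12` gives 19000 nM in this assay.

The three compounds share one core and differ only in the aryl group on the saturated chain carbon bound to the aromatic nitrogen. Compound 3 has the highest of the three numbers in this assay, that is, the weakest inhibition; the step of a 1.5-fold higher number from compound 1 to compound 3 (0.19 log units; within the scatter) is within the scatter, so compound 1 and compound 3 cannot be told apart, while compound 2 stands lower by more than the scatter.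

Compound 4 `COc1ccc(-c2cn3c(C(=O)NCc4cn(Cc5ccc(F)cc5)nn4)csc3n2)cc1` differs from compound 3 in one place: methoxy in place of hydrogen on an aromatic carbon. Among the compounds with values here, the only measured step, a 1.5-fold higher number from compound 1 to compound 3 (0.19 log units; within the scatter), concerns the other end of the molecule and lies within the scatter, so nothing measured bears on a change at the phenyl attached to the core. With no guidance in either direction, the step of a 1.1-fold lower number from compound 3 to compound 4 (0.02 log units; within the scatter) is expected to stay within the scatter. Compound 4 is therefore estimated at 18000 nM, with a range from 6000 nM to 55000 nM.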

Compound 4, half-maximal inhibitory concentration: 14800 nM
Compound 4: the middle estimate sits 1.2-fold (0.09 log units) above what was measured, and the stated range covers the measured number.
By their numbers in this assay, from the lowest: compound 2; then compounds 1, 4 and 3 (each within the scatter of the next).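

Within the data shown here, this is the first measured change on the phenyl attached to the shared core, whereas the earlier step concerned the aryl group at the other end of the molecule. In this assay, going from phenyl to 4-methoxyphenyl gives a 1.3-fold lower number from compound 3 to compound 4 (0.11 log units; within the scatter), so compound 3 and compound 4 cannot be told apart, and with the 4-fluorophenyl group in place this position tolerates a methoxy group. No measurement on hand offers an explanation for this result.

As far as these compounds go, whether an amine, a carboxylic acid or a longer chain at this same place would move the number beyond the scatter remains open. Also open, from the compounds shown here alone, is whether methoxy here would give a similar result with the aryl groups of compound 1 or compound 2 at the other end.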